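Swapping one substituted phenyl group on compound 3

The source may hold more compounds than are shown below. What is called first, only, known or untested is meant among the compounds shown, and "the series" means these compounds.

Measured in a physicochemical assay for solubility, measured as kinetic solubility, at pH 6.5; a higher number here means a more soluble compound, a lower number a less soluble compound:
- Compound 1 `Fc1ccc(-c2ccc3nnc(Cc4ccc5ncccc5c4)n3n2)cc1F` gives 11500 nM
- Compound 2 `Nc1ccc2nnc(Cc3ccc4ncccc4c3)n2n1` gives 453000 nM
- Compound 3 `COc1ccc(-c2ccc3nnc([C@@H](C)c4ccc5ncccc5c4)n3n2)cc1F` gives 10900 nM

Compound 3 lies within the scatter of compound 1 and far under compound 2. Compound 4 `Cc1cccc(-c2ccc3nnc([C@@H](C)c4ccc5ncccc5c4)n3n2)c1` carries 3-methylphenyl in place of 3-fluoro-4-methoxyphenyl on an aromatic carbon. Going by the values given here, the one measured step is large (a 39-fold higher number from compound 1 to compound 2 (1.60 log units; beyond the scatter)), but it puts amino where a substituted phenyl stood, so it bears only weakly on a swap of one substituted phenyl for another. Compound 1 and compound 3, which both carry a substituted phenyl, have values within the scatter of each other. No step beyond the scatter is therefore expected in this assay here. The estimated step is small (a 1.1-fold lower number from compound 3 to compound 4 (0.04 log units; within the scatter)). Compound 4 is estimated at 10000 nM (expected range 3500 nM to 28000 nM).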

Compound 4, solubility: 19000 nM
The estimate for compound 4 lay 1.9-fold (0.28 log units) below the measured number; measured number inside the range.
By their numbers in this assay, from the lowest: compounds 3, 1 and 4 (each within the scatter of the next); then compound 2.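

In this assay the change from 3-fluoro-4-methoxyphenyl to 3-methylphenyl gives a 1.7-fold higher number from compound 3 to compound 4 (0.24 log units; within the scatter) and so shows that, on this aromatic carbon, one substituted phenyl can replace another with no step beyond the scatter. Going by these compounds alone, this is the first direct comparison of two substituted phenyl groups here, with the core held the same. No measured evidence explains this result.

Going by these compounds, the fluorine and the methoxy group leave together, so their separate contributions stay unknown. Also open, on these data alone, is what a morpholine or a carboxylic acid would give on this carbon.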